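From furan-3-yl to thiophen-2-yl at the assay limit

The compounds below may be only part of what the source reports. "The series", "measured", "known", "first", "only" and "open" are said of these compounds alone.

Measured in a functional assay on HL-60 cells (Homo sapiens) for antiproliferative activity, read by XTT assay, with a stated time of 72 h; a higher number here means a weaker inhibitor, a lower number a stronger inhibitor:
Compound 1 `Nc1nc(N)c2c(-c3cccs3)cn([C@@H]3O[C@H](CO)[C@@H](O)[C@H]3O)c2n1`: > 20000 nM
Compound 2 `Cc1nc(N)c2c(-c3ccco3)cn([C@@H]3O[C@H](CO)[C@@H](O)[C@H]3O)c2n1`: > 20000 nM
Compound 3 `Cc1nc(N)c2c(-c3ccoc3)cn([C@@H]3O[C@H](CO)[C@@H](O)[C@H]3O)c2n1`: > 20000 nM

Each of these entries is a limit of the assay and not a number. Compound 3 therefore has no measured potency of its own, and it stands with the other two compounds at the limit of > 20000 nM in this assay, at which 3 of the 3 values shown sit, with no order among them.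

The next compound, compound 4 `Cc1nc(N)c2c(-c3cccs3)cn([C@@H]3O[C@H](CO)[C@@H](O)[C@H]3O)c2n1`, changes one group of compound 3: thiophen-2-yl in place of furan-3-yl on an aromatic carbon. The thiophen-2-yl group sits on an aromatic carbon of a five-membered aromatic ring with 1 nitrogen.

Among the compounds with values here, the only measured step that swaps one such ring group for another is a step that the two limits leave unreadable from compound 2 to compound 3, so it offers no size to carry over. Compound 1 also bears thiophen-2-yl, although its core differs from that of compound 4. Compound 1 stands at > 20000 nM, which is again a limit.

With no readable step to go on, no change beyond the scatter is expected in this assay, and a further limit is the likeliest result. The estimated change is a step that the limit leaves unreadable from compound 3 to compound 4. For compound 4 the estimated value is 25000 nM, with an expected range from 8000 nM to 60000 nM.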

Compound 4, half-maximal inhibitory concentration: > 20000 nM
Compound 4: only a limit was reported (the forecaster's own chance of this, stated with the estimate: 80%); the middle value is on the limit's open side.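

Compound 4, like compound 1, compound 2 and compound 3, gives only a limit and not a number in this assay, so no step among these four compounds can be read: the limit of > 20000 nM in this assay, at which 4 of the 4 values shown sit.

The compounds shown leave open whether swapping these ring groups, or methyl for amino, changes potency at all.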